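A few compounds are considered here, and "the series" means these few. Any claim that something is new, unique, unknown or untested is made for them only; others in the source may bear on it.

Compound 1 `O=C1COc2ccccc2N1CCCn1cc(-c2ccccc2)nn1`: 94000 nM
Compound 2 `COc1ccc2cc(-c3cn(CCCN4C(=O)COc5ccccc54)nn3)ccc2c1`: > 100000 nM (a limit of the assay)

Within the data shown here, in a functional assay on MiaPaCa cells (Homo sapiens) for antiproliferative activity, read by sulforhodamine B assay, with a stated time of 48 h (a lower number here means a stronger inhibitor of growth, a higher number a weaker inhibitor of growth), compound 1 gives 94000 nM, the only actual number so far. Compound 2 stands at > 100000 nM, which is a limit of the assay. Compound 3 `CCCCCCc1cn(CCCN2C(=O)COc3ccccc32)nn1` differs from compound 1 by hexyl in place of phenyl on an aromatic carbon. Among the measured compounds shown here, no measured pair shows what such a change does, so the expectation is only a modest gain in growth inhibition, possibly no more than the scatter. The expected change is a 1.7-fold lower number from compound 1 to compound 3 (0.23 log units; within the scatter). For compound 3 the estimated value is 55000 nM, with an expected range of 18000 nM to 100000 nM.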

Compound 3, concentration for 50% growth inhibition: 150 nM
Estimate against measurement, compound 3: 370-fold (2.56 log units) above; the measured number lies below the stated range.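

On an aromatic carbon of the five-membered aromatic ring, hexyl in place of phenyl, with the same number of heavy atoms, gives a 630-fold lower number from compound 1 to compound 3 (2.80 log units; beyond the scatter) in this assay. This position is therefore far from indifferent to what it carries, which compound 1 and compound 2, both with aromatic rings here, did not reveal. Those two alone gave little to read in this assay: the limit of > 100000 nM in this assay, at which 1 of the 3 values shown sits.

Still open, going by these compounds, is whether the open chain, its length or the loss of the aromatic ring matters most. A butyl chain, an octyl chain or a cyclohexyl ring at this carbon would separate these.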